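Notes on compound 3 of the imidazoline ether series

The source may hold more compounds than are shown below. What is called first, only, known or untested is meant among the compounds shown, and "the series" means these compounds.

In a functional assay for activation of Alpha-1B adrenergic receptor (Homo sapiens), read by calcium flux (on this read-out higher numbers stand for an effect only at larger amounts of compound and lower numbers for an effect already at smaller amounts), compound 1 `c1ccc(-c2ccncc2)c(OCC2=NCCN2)c1` gives < 100000 nM, which is a limit of the assay. In this assay compound 2 `c1ccc(-c2ccncn2)c(OCC2=NCCN2)c1` likewise gives < 100000 nM, again a limit of the assay. The step that the two limits leave unreadable from compound 1 to compound 2 therefore cannot be sized; both readings sit at the limit of < 100000 nM in this assay, at which 2 of the 2 values shown sit. Compound 2 thus stands only at a limit, with no number of its own in this assay.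

Compound 3 `c1csc(-c2ccccc2OCC2=NCCN2)c1`, not yet measured in this assay, differs from compound 2 by thiophen-2-yl in place of pyrimidin-4-yl on an aromatic carbon. Within the data shown here, the one measured step, a step that the two limits leave unreadable from compound 1 to compound 2, concerns a change on the same aromatic carbon but is unreadable, so neither size nor direction can be drawn from it for compound 3 in this assay. For compound 3 the estimate in this assay is 30000 nM, with a range from 3000 nM to 100000 nM. The step that the limit leaves unreadable from compound 2 to compound 3 that this estimate implies is expected to remain unreadable, with the reading most likely again at a limit.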

Compound 3, half-maximal effective concentration: 3.98 nM
Compound 3: the middle estimate sits 7500-fold (3.88 log units) above what was measured; measured number below the stated range.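

The steps from compound 1 and from compound 2 to compound 3 in this assay cannot be read, because compound 1 and compound 2 stand only at a limit: the limit of < 100000 nM in this assay, at which 2 of the 3 values shown sit. The compounds shown leave open how far thiophen-2-yl actually separates from pyridin-4-yl or pyrimidin-4-yl in this assay on this aromatic carbon.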